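A few compounds are considered here, and "the series" means these few. Any claim that something is new, unique, unknown or untested is made for them only; others in the source may bear on it.

Compound 3 `Nc1ccccc1NC(=O)c1ccc(Cn2cnc3c(NCc4ccccc4)nc(Cl)nc32)cc1` gives 62.8% in a functional assay on HepG2 cells (Homo sapiens) for antiproliferative activity, read by CCK-8 assay, with a stated time of 72 h, tested at 8 uM (on this read-out higher numbers stand for a stronger effect at the one concentration tested and lower numbers for a weaker effect), which places it second highest among the three compounds measured. Compound 1 `Cc1ccc(Nc2nc(Cl)nc3c2ncn3Cc2ccc(C(=O)Nc3ccccc3N)cc2)cc1` gives 82%, and compound 2 `CC1CCN(c2nc(Cl)nc3c2ncn3Cc2ccc(/C=C/C(=O)Nc3ccccc3N)cc2)CC1` gives 32.2%. Within the data shown here, the one step that alters the same aromatic carbon, a number 19.2 percentage points lower from compound 1 to compound 3 (beyond the scatter), already moved the read-out downward by a modest but real margin. Compound 4 `CC1CCN(c2nc(Cl)nc3c2ncn3Cc2ccc(C(=O)Nc3ccccc3N)cc2)CC1` differs from compound 3 in a single place: 4-methylpiperidin-1-yl in place of benzylamino on an aromatic carbon. Among the measured compounds shown here, no measured step bears directly on this exchange. The same 4-methylpiperidin-1-yl group is also carried by compound 2, which differs from compound 4 elsewhere as well; in this assay compound 2 gives 32.2%, which can only hint that this group sits on the weaker side of the series. Taking the downward step from compound 1 to compound 3 together with the low value of compound 2, a further decrease is expected for compound 4, with a number 16.8 percentage points lower from compound 3 to compound 4 (beyond the scatter). Compound 4 is therefore estimated at 46% in this assay, within a range of 24% to 68%.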

Compound 4, a percentage reported as inhibition, at one concentration (the size of the read-out at that concentration, not a potency): 65.3%
Beside the measured number, compound 4's estimate is 19.3 percentage points below it; measured number inside the range.
By their numbers in this assay, from the lowest: compound 2; then compounds 3 and 4 (each within the scatter of the next); then compound 1.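

In this assay the exchange of benzylamino for 4-methylpiperidin-1-yl on this aromatic carbon gives a number 2.5 percentage points higher from compound 3 to compound 4 (within the scatter) and so shows that this position tolerates a group with no aromatic ring and no hydrogen-bond donor without a change that can be told from the scatter. With 4-methylpiperidin-1-yl held constant, (2-aminophenyl)carbamoyl in place of 2-((2-aminophenyl)carbamoyl)ethenyl gives a number 33.1 percentage points higher from compound 2 to compound 4 (beyond the scatter) and shows that 4-methylpiperidin-1-yl does not by itself go with the low value of compound 2. The exchange of (4-methylphenyl)amino for the same group gives a number 16.7 percentage points lower from compound 1 to compound 4 (beyond the scatter) and sets (4-methylphenyl)amino apart from 4-methylpiperidin-1-yl at this carbon.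

The compounds shown leave open whether morpholin-4-yl or dimethylamino on this carbon would fall in the same range. Nothing given here accounts for these differences.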